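The source may report more compounds than this note shows. Statements on the series, on what has been measured and on what is new or still open speak of the compounds shown alone.

Compound 1, `Cc1ccc(COc2c(-c3ccccc3)c(-c3ccccc3)n3ccc(C#N)cc23)cc1`: in an assay for inhibition of Polyunsaturated fatty acid lipoxygenase ALOX15 (Oryctolagus cuniculus) (on this read-out lower numbers stand for stronger inhibition and higher numbers for weaker inhibition), compound 1 gives "not determined" (no result reported).
Compound 2, `N#Cc1ccn2c(-c3ccccc3)c(-c3ccccc3)c(OCc3cccc(Cl)c3)c2c1`: in this assay compound 2 gives "not determined" (no result reported).
Compound 3, `N#Cc1ccn2c(-c3ccccc3)c(-c3ccccc3)c(OCOCc3ccccc3)c2c1`: in this assay compound 3 gives 39000 nM.

Among these three compounds, compound 3 carries the only number; compounds 1 and 2 were not measured, so no comparison between them can be drawn. The number for compound 3 marks only weak inhibition on this scale.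

Compound 4, `N#Cc1ccn2c(-c3ccccc3)c(-c3ccccc3)c(CO)c2c1`, has not yet been tested. It differs from compound 3 in one place: hydroxymethyl in place of (benzyloxy)methoxy on an aromatic carbon. Within the data shown here, no measured pair in this set shows what such a change does, so the expectation rests on compound 3 alone and on the size of the change. Because compound 3 already gives 39000 nM, compound 4 is expected to remain a weak inhibitor, and the step of a 1.5-fold higher number from compound 3 to compound 4 (0.19 log units; within the scatter) is expected to lean toward weaker inhibition rather than stronger, though it may well stay within the scatter. Compound 4 is therefore estimated at 60000 nM, with a range from 15000 nM to 200000 nM, and a fair chance that only a limit is reported.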

Compound 4, half-maximal inhibitory concentration: 34000 nM
The estimate for compound 4 lay 1.8-fold (0.25 log units) above the measured number; the measured number falls inside the stated range.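

In this assay the exchange of (benzyloxy)methoxy for the far smaller hydroxymethyl on this aromatic carbon amounts to a 1.1-fold lower number from compound 3 to compound 4 (0.06 log units; within the scatter) and no more. The two compounds therefore cannot be told apart on this read-out, even though the group that leaves carries a six-membered aromatic ring and no hydrogen-bond donor, while the group that enters has no ring and one donor. No supporting measurement bears on this result.

What the compounds shown leave open is whether a group of another kind on this carbon, such as an amine or a carboxylic acid, would give a number clearly apart from these two. As far as these compounds go, it also remains open whether a longer chain ending in an amide would do so, and in which direction.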